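The compounds below may be only part of what the source reports. "The series", "measured", "known", "first", "only" and "open" are said of these compounds alone.

In a physicochemical assay for lipophilicity, using the shake flask method (on this read-out lower numbers stand for lower lipophilicity and higher numbers for higher lipophilicity), compound 2 `CC(C)(C)OC(=O)N/N=C/c1c(N)ncnc1Oc1ccc(NC(=O)C2(C(=O)Nc3ccc(F)cc3)CC2)cc1F` gives 3.7, the higher of the two numbers measured, while compound 1 `Nc1ncnc(Oc2ccc(NC(=O)C3(C(=O)Nc4ccc(F)cc4)CC3)cc2F)c1/C=N/O` gives 2.62. For the measured compounds named here, the one measured step, a number 1.08 log units higher from compound 1 to compound 2 (beyond the scatter), put a group on the double-bonded nitrogen in place of hydroxy. Compound 3 `Nc1ncnc(Oc2ccc(NC(=O)C3(C(=O)Nc4ccc(F)cc4)CC3)cc2F)c1/C=N/OCc1ccccc1` carries a different change at that position: benzyloxy in place of (tert-butoxycarbonyl)amino on a double-bonded nitrogen. Going by the values given here, no measured step covers this exchange, so the expectation rests on the step to compound 2 alone. For compound 3 an upward step a number 0.60 log units higher from compound 2 to compound 3 (beyond the scatter) is estimated, giving an expected value of 4.3, within a range from 3.6 to 5.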

Compound 3, partition coefficient: 4.45
Beside the measured number, compound 3's estimate is 0.15 log units below it; low and high end bracket the measured number.
By their numbers in this assay, from the lowest: compound 1; then compound 2; then compound 3.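

In this assay, exchanging one group on the double-bonded nitrogen for another of 8 heavy atoms still moves the number: a number 0.75 log units higher from compound 2 to compound 3 (beyond the scatter). Heavy-atom count alone therefore does not set the value in this pair. Benzyl in place of hydrogen on an oxygen gives the largest step among these compounds, a number 1.83 log units higher from compound 1 to compound 3 (beyond the scatter). As far as these compounds go, how a methoxy group or a carboxylic acid at this place would compare remains open. Nothing available here explains why the number moves with these changes.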